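The source may hold more compounds than are shown below. What is called first, only, known or untested is meant among the compounds shown, and "the series" means these compounds.

Notes on the series

Two members of the series have been run in an ADME assay on RAW264.7 cells (Mus musculus) for cytotoxicity, read by MTT assay, with a stated time of 72 h, tested at 50 uM; a lower number here means less inhibition, a higher number more inhibition at the concentration tested (going by the name of the read-out). Compound 1 `CCOC(=O)c1sc(-c2ccccn2)nc1N1CCC(NCc2ccc(C(F)(F)F)cc2)CC1` gives 14.6%. Within the data shown here, compound 2 `CCOC(=O)c1sc(-c2ccccn2)nc1N1CCC(NCc2ccc(Cl)c(Cl)c2)CC1` gives 30.1%, the higher of the two numbers; the step of a number 15.5 percentage points higher from compound 1 to compound 2 (beyond the scatter) is the only measured step and it lies beyond the scatter. On the numbers shown, compound 2 stands highest, with compound 1 as its nearest neighbour.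

Compound 3 `CCOC(=O)c1sc(-c2ccccn2)nc1N1CCC(NCc2ccc(Cl)cc2Cl)CC1` has not yet been measured in this assay. It differs from compound 2 as follows: 2,4-dichlorophenyl in place of 3,4-dichlorophenyl on a saturated chain carbon bound to an amine nitrogen. Among the measured compounds shown here, no measured step covers this change; the only step available, from compound 1 to compound 2, swaps one substituent pattern for another of a different make-up, so it gives no direct guide to a rearrangement of the same two chlorines. With nothing beyond that single step to lean on, no movement beyond the scatter is expected from compound 2 to compound 3, and the estimated step is a number 3.1 percentage points lower from compound 2 to compound 3 (within the scatter). Compound 3 is therefore expected to read about 27% in this assay, with a range from 12% to 44%.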

Compound 3, a percentage reported as inhibition, at one concentration (the size of the read-out at that concentration, not a potency): 18.6%
Beside the measured number, compound 3's estimate is 8.4 percentage points above it; low and high end bracket the measured number.
By their numbers in this assay, from the lowest: compounds 1 and 3 (each within the scatter of the next); then compound 2.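

In this assay, the place on a saturated chain carbon bound to an amine nitrogen responds to the arrangement of the two chlorines alone: with the same atoms joined differently, 2,4-dichlorophenyl in place of 3,4-dichlorophenyl gives a number 11.5 percentage points lower from compound 2 to compound 3 (beyond the scatter). The 2,4-dichlorophenyl and 4-(trifluoromethyl)phenyl groups are not told apart here, with a number 4 percentage points higher from compound 1 to compound 3 (within the scatter), so the presence of two chlorines does not by itself go with the higher reading, and among these three compounds only the 3,4-dichlorophenyl group of compound 2 stands apart. Nothing available on these compounds accounts for this difference.

The compounds shown leave open how a single chlorine would read at this place, as in 3-chlorophenyl or 4-chlorophenyl, and whether the 3,4-dichlorophenyl reading would persist with a different arrangement of the same atoms, such as 2,3-dichlorophenyl or 3,5-dichlorophenyl. They also leave open whether a methoxy group or a nitrile on the phenyl ring, or a carboxylic acid in place of the ethyl ester on the shared core, would move the reading beyond the scatter.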